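Notes on exchanging 3-nitrophenyl for 4-chlorophenyl

The compounds below may be only part of what the source reports. "The series", "measured", "known", "first", "only" and "open" are said of these compounds alone.

In a functional assay on HT-29 cells (Homo sapiens) for cytotoxicity, read by sulforhodamine B assay (on this read-out higher numbers stand for weaker inhibition of growth and lower numbers for stronger inhibition of growth), compound 1 `CC1=CC[C@@H]([C@@](C)(O)CCCC(C)(C)NC(=S)NN)CC1` gives 49400 nM, compound 2 `COc1ccc(/C=N\NC(=S)NC(C)(C)CCC[C@](C)(O)[C@@H]2CC=C(C)CC2)cc1` gives 7420 nM and compound 3 `CC1=CC[C@@H]([C@@](C)(O)CCCC(C)(C)NC(=S)N/N=C\c2cccc([N+](=O)[O-])c2)CC1` gives 14100 nM. The number for compound 3 lies under that for compound 1 and within the scatter of compound 2.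

Compound 4 `CC1=CC[C@@H]([C@@](C)(O)CCCC(C)(C)NC(=S)N/N=C\c2ccc(Cl)cc2)CC1` carries 4-chlorophenyl in place of 3-nitrophenyl on a carbon with a double bond to nitrogen.

For the measured compounds named here, two measured steps bear on this change. The closest is a 1.9-fold higher number from compound 2 to compound 3 (0.28 log units; within the scatter), an exchange of one substituted phenyl for another at the same place, and it stays within the scatter. The other, a 6.7-fold lower number from compound 1 to compound 2 (0.82 log units; beyond the scatter), goes beyond the scatter, but it introduces the aromatic group, which compound 4 keeps, so it says little about an exchange. Going by the values given here, no compound with chlorine has been measured. No step beyond the scatter is therefore expected in this assay.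

The expected change is a 1.4-fold lower number from compound 3 to compound 4 (0.15 log units; within the scatter). The estimate for compound 4 is 10000 nM, with an expected range of 4500 nM to 22000 nM.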

Compound 4, concentration for 50% growth inhibition: 7350 nM
Compound 4: the middle estimate sits 1.4-fold (0.13 log units) above what was measured, and the stated range covers the measured number.
By their numbers in this assay, from the lowest: compounds 4, 2 and 3 (each within the scatter of the next); then compound 1.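

In this assay, 4-chlorophenyl in place of 3-nitrophenyl on a carbon with a double bond to nitrogen gives a 1.9-fold lower number from compound 3 to compound 4 (0.28 log units; within the scatter) and stays within the scatter, and chloro in place of methoxy on an aromatic carbon gives a 1.0-fold lower number from compound 2 to compound 4 (0.00 log units; within the scatter) and does the same, so all three substituted phenyl groups now read alike at this place. The step that adds the aromatic group holds with chlorine as well, at a 6.7-fold lower number from compound 1 to compound 4 (0.83 log units; beyond the scatter) and beyond the scatter, so the only clear difference in this set separates compound 1 from the three compounds with a substituted phenyl group. No measurement at hand explains why the three groups read alike.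

Still open, from the compounds shown here alone, is whether an unsubstituted phenyl, or an amine or carboxylic acid on the phenyl ring, would stay in this range. The effects of substituent and ring place also remain unseparated, since 3-nitrophenyl and 4-chlorophenyl differ in both.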